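The compounds below may be only part of what the source reports. "The series", "measured", "known", "first", "only" and "open" are said of these compounds alone.

Compound 1 `CC(O)(CSc1ccc(S(F)(F)(F)(F)F)cc1)C(=O)Nc1ccc(S(F)(F)(F)(F)F)cc1` and compound 2 `CC(O)(CSc1ccc(F)cc1)C(=O)Nc1ccc(S(F)(F)(F)(F)F)cc1` share one core. In a functional assay on VCaP cells (Homo sapiens) for antiproliferative activity, read by propidium iodide staining, with a stated time of 96 h (a lower number here means a stronger inhibitor, a higher number a weaker inhibitor), compound 1 gives 28000 nM, and compound 2 gives 23000 nM. The change between them is one fluorine atom in place of a group of 6 heavy atoms (5 fluorine, 1 sulfur; no ring), on an aromatic carbon and the step it made is a 1.2-fold lower number from compound 1 to compound 2 (0.09 log units; within the scatter). Compound 3 `CC(O)(CSc1ccc(S(F)(F)(F)(F)F)cc1)C(=O)Nc1cccc(S(F)(F)(F)(F)F)c1` is built from the same atoms as compound 1, joined differently; the difference between the two cores is not broken down here. In this assay compound 3 gives 24100 nM, near both earlier numbers. Compound 4 `CC(O)(CSc1ccc(F)cc1)C(=O)Nc1cccc(S(F)(F)(F)(F)F)c1` stands to compound 3 as compound 2 stands to compound 1: one fluorine atom in place of a group of 6 heavy atoms (5 fluorine, 1 sulfur; no ring), on an aromatic carbon This is the same change as before, at the same place. For compound 4 a step of similar size is expected, a 1.1-fold lower number from compound 3 to compound 4 (0.06 log units; within the scatter), because a 1.2-fold lower number from compound 1 to compound 2 (0.09 log units; within the scatter) stayed within the scatter. Compound 4 is therefore estimated at 21000 nM, with a likely range from 10000 nM to 45000 nM.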

Compound 4, half-maximal inhibitory concentration: 21900 nM
For compound 4 the middle estimate is 1.0-fold (0.02 log units) below the measured one; the range from low to high includes it.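

In this assay, fluoro in place of the group of 6 heavy atoms gives a 1.1-fold lower number from compound 3 to compound 4 (0.04 log units; within the scatter), and the two cores show no readable difference in this change: the same change on two cores in this assay, a 1.2-fold lower number (0.09 log units; within the scatter) from compound 1 to compound 2 and a 1.1-fold lower number (0.04 log units; within the scatter) from compound 3 to compound 4, 1.1-fold (0.04 log units) apart, within the scatter of two such steps. Within the data shown here, both steps lie within the scatter, so the agreement shows only that the change leaves the number unmoved on these two cores. It does not show that the change would behave alike on a core with a much lower number, nor does it test transfer of a step large enough to read.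

Open, on these data alone, is whether another group at this place, such as an amine, a carboxylic acid or a nitrile, would move the number beyond the scatter. Also open, as far as these compounds go, is whether a longer chain in place of the methyl would do so.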